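This account rests on a few compounds, and the source may have more. Where it says the series, first, only, none or still open, it means among the compounds named here.

In a functional assay on ECa-109 cells (Homo sapiens) for cytotoxicity, read by MTT assay, with a stated time of 48 h (on this read-out higher numbers stand for weaker inhibition and lower numbers for stronger inhibition), two compounds have been read so far. Compound 1 `COc1ccccc1C(C1=C(O)C(=O)c2ccccc2C1=O)c1c[nH]c2ccccc12` gives > 200000 nM, which is a limit of the assay and not a number. Within the data shown here, the only evidence on where compound 1 stands is therefore (the limit of > 200000 nM in this assay, at which 1 of the 2 values shown sits). Compound 2 `Cc1[nH]c2ccccc2c1C(C1=C(O)C(=O)c2ccccc2C1=O)c1ccc(Cl)cc1` gives a measured 14300 nM. Compound 3 `O=C1C(O)=C(C(c2cccs2)c2c[nH]c3ccccc23)C(=O)c2ccccc21` has thiophen-2-yl in place of the 2-methoxyphenyl of compound 1, on a saturated chain carbon bound to an aromatic carbon and a double-bonded ring carbon: thiophen-2-yl in place of 2-methoxyphenyl on a saturated chain carbon bound to an aromatic carbon and a double-bonded ring carbon. Among the measured compounds shown here, no measured step between compounds is available to size this change. For the measured compounds named here, compound 2, at 14300 nM, gives the only numerical guide, and it points towards stronger inhibition. The expected change is an at least 5.0-fold lower number from compound 1 to compound 3 (0.69 log units; beyond the scatter), in the direction of stronger inhibition, with its size uncertain. For compound 3 the estimated value in this assay is 40000 nM, with an expected range of 10000 nM to 180000 nM.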

Compound 3, half-maximal inhibitory concentration: 12100 nM
For compound 3 the middle estimate is 3.3-fold (0.52 log units) above the measured one, and the stated range covers the measured number.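

In this assay, among these compounds, thiophen-2-yl in place of 2-methoxyphenyl on a saturated chain carbon bound to an aromatic carbon and a double-bonded ring carbon gives an at least 16-fold lower number from compound 1 to compound 3 (1.21 log units; beyond the scatter), the first step that can be sized at this position. The true size of the step is open, since its starting point is a limit of the assay and not a number: the limit of > 200000 nM in this assay, at which 1 of the 3 values shown sits. Even so, the step shows that the read-out responds to the group at this position, and that the exchange of a six-membered aromatic ring of carbon only for a five-membered aromatic ring with 1 hetero atom lowers the number beyond the scatter.

The compounds shown leave open how a plain phenyl or furan-2-yl at this carbon would read, and so whether the step follows from the entry of thiophen-2-yl or the departure of 2-methoxyphenyl. They also leave open what an amine or a carboxylic acid carried at this carbon would do.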